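Amide side chain variation in an antiproliferative series

The compounds below may be only part of what the source reports. "The series", "measured", "known", "first", "only" and "open" are said of these compounds alone.

Measured compounds:
compound 1 `COc1cc2ncnc(N3CCCc4ccccc43)c2cc1NC(=O)C=C(C)C` 6130 nM
compound 2 `COc1cc2ncnc(N3CCCc4ccccc43)c2cc1NC(=O)/C=C/C(C)C` 8430 nM

In a functional assay on PC-3 cells (Homo sapiens) for antiproliferative activity, read by MTT assay, with a stated time of 72 h (on this read-out higher numbers stand for weaker inhibition and lower numbers for stronger inhibition), compound 2 gives the highest of the two numbers; compound 1 lies nearest, and the step of a 1.4-fold higher number from compound 1 to compound 2 (0.14 log units; within the scatter) is within the scatter. Compound 3 `COc1cc2ncnc(N3CCCc4ccccc43)c2cc1NC(=O)/C=C/CN(C)C` differs from compound 2 by (dimethylamino)methyl in place of isopropyl on a double-bonded chain carbon bound to a double-bonded chain carbon. Going by the values given here, only the one step from compound 1 to compound 2 bears on this place in the chain, and it was small. Among the compounds with values here, no measured step covers a nitrogen entering there, so the direction is open. For compound 3 in this assay the expected value is 5500 nM, range 1800 nM to 17000 nM, an expected step of a 1.5-fold lower number from compound 2 to compound 3 (0.19 log units; within the scatter) from compound 2.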

Compound 3, half-maximal inhibitory concentration: 1750 nM
Compound 3: middle estimate off by 3.1-fold (0.50 log units), on the high side; measured number below the stated range.
By their numbers in this assay, from the lowest: compound 3; then compounds 1 and 2 (each within the scatter of the next).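

Here a 4.8-fold lower number from compound 2 to compound 3 (0.68 log units; beyond the scatter) comes with (dimethylamino)methyl in place of isopropyl on a double-bonded chain carbon bound to a double-bonded chain carbon, the first change at this place to go beyond the scatter in this assay. The other all-carbon chain gives the same direction, with a 3.5-fold lower number from compound 1 to compound 3 (0.54 log units; beyond the scatter), so the amine-bearing chain stands apart from both. No measurement here bears on the cause of this shift.

Going by these compounds, whether the dimethylamino group is specifically required remains open, since a piperidine, a morpholine or a primary amine could be compared at this place. Also open, on these data alone, is how a longer chain carrying the amine would read out.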